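Hydroxamic acid triazoles: a step toward an isoquinoline substituent

The source may report more compounds than this note shows. Statements on the series, on what has been measured and on what is new or still open speak of the compounds shown alone.

Measured compounds in an assay on Sf9 cells for inhibition of protein deacetylase HDAC6 (Homo sapiens), read by fluorescence, with a stated time of 40 min, tested at 100 nM; a higher number here means more inhibition at the concentration tested (going by the name of the read-out), a lower number less inhibition:
Compound 1 `Cc1ccc(-c2nc(CNc3ccc(C(=O)NO)cc3)n(-c3ccccc3)n2)cc1` gives 62.2%.
Compound 2 `Cc1cccc(-n2nc(-c3ccccc3)nc2CNc2ccc(C(=O)NO)cc2)c1` gives 66%.
Compound 3 `O=C(NO)c1ccc(NCc2nc(-c3ccccc3)nn2-c2ccc(Cl)cc2)cc1` gives 55.4%.

Compound 1 holds the second highest of the three numbers; its gap to compound 2 and its gap to compound 3 both lie within the scatter, so no order among the three can be claimed. Going by the values given here, the only step measured between two compounds that differ in one place is a number 10.6 percentage points lower from compound 2 to compound 3 (beyond the scatter), a modest change made on an aromatic nitrogen, not at the position that matters here.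

Compound 4 `O=C(NO)c1ccc(NCc2nc(-c3cccc4cnccc34)nn2-c2ccccc2)cc1` differs from compound 1 in this way: isoquinolin-5-yl in place of 4-methylphenyl on an aromatic carbon. The group that leaves is 4-methylphenyl and the group that enters is isoquinolin-5-yl, on an aromatic carbon of the five-membered ring with three nitrogen, between two ring nitrogen atoms. Among the compounds with values here, no measured step touches this place, so the data give no guide to the size or direction of the change. The expected step is therefore a number 2.2 percentage points lower from compound 1 to compound 4 (within the scatter), that is, none beyond the scatter. Compound 4 is estimated at 60%, within 44% to 76%.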

Compound 4, a percentage reported as inhibition, at one concentration (the size of the read-out at that concentration, not a potency): 40.2%
Compound 4: middle estimate off by 19.8 percentage points, on the high side; the measured number lies below the stated range.
By their numbers in this assay, from the lowest: compound 4; then compounds 3, 1 and 2 (each within the scatter of the next, the first and the last beyond it).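

The first step measured at this carbon of the five-membered ring shows that the position is not indifferent to its substituent: in this assay, isoquinolin-5-yl in place of 4-methylphenyl gives a number 22 percentage points lower from compound 1 to compound 4 (beyond the scatter) and so moves the result beyond the scatter. The earlier compounds shown here showed a change only on an aromatic nitrogen, and this step extends that sensitivity to the aromatic carbon on the other side of the core. No evidence at hand accounts for the lower number.

Still open, on these data alone, is whether the lower number goes with the second six-membered ring or with the ring nitrogen of isoquinolin-5-yl. A naphthyl group and a pyridyl group on this carbon would separate the two, and a comparison of the pair would show which part of the change carries the step.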